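The source may hold more compounds than are shown below. What is called first, only, known or untested is meant among the compounds shown, and "the series" means these compounds.

Measured so far in a physicochemical assay for solubility, read by HPLC, using the shake flask method, with a stated time of 2 h, at pH 2; on this read-out higher numbers stand for higher solubility and lower numbers for lower solubility:
Compound 1 `Nc1ncc(-c2ccc(C(=O)N3CC[C@@H](O)C3)cc2)nc1-c1ccc(C(F)(F)F)cc1`: 103000 nM
Compound 2 `Nc1ncc(-c2ccc(C(=O)N3CC[C@H](O)C3)cc2)nc1-c1ccc(C(F)(F)F)cc1`: 93000 nM

Compound 2, at 93000 nM, cannot be told apart from compound 1 on these numbers. Among the measured compounds shown here, the one measured step, a 1.1-fold lower number from compound 1 to compound 2 (0.04 log units; within the scatter), stays within the scatter, and the pair differ only in configuration, as the fact that compounds 1 and 2 differ only in the configuration as drawn records. Compound 3 `Nc1ncc(-c2ccc(C(=O)O)cc2)nc1-c1ccc(C(F)(F)F)cc1` departs from compound 2 in a larger way: hydroxy in place of 3-hydroxypyrrolidin-1-yl on a carbonyl carbon. Put simply, hydroxy stands in place of 3-hydroxypyrrolidin-1-yl on a carbonyl carbon. The measured step leaves this group in place, so it gives no measure of the change, and the expectation is a matter of judgement. Starting from compound 2 at 93000 nM, a fall in this assay beyond the scatter is expected, though with wide uncertainty. The expected step is a 9.3-fold lower number from compound 2 to compound 3 (0.97 log units; beyond the scatter). For compound 3 the estimated value is 10000 nM, with an expected range from 1500 nM to 60000 nM.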

Compound 3, solubility: < 5000 nM
Compound 3: only a limit was reported (the forecaster's own chance of this, stated with the estimate: 10%); middle value at least 2.0-fold (0.30 log units) away from the limit.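

In this assay, among the compounds shown here, the change from 3-hydroxypyrrolidin-1-yl to hydroxy on a carbonyl carbon gives an at least 18-fold lower number from compound 2 to compound 3 (1.26 log units; beyond the scatter) and also an at least 20-fold lower number from compound 1 to compound 3 (1.31 log units; beyond the scatter), the first steps beyond the scatter in this set. Compound 3 stands at < 5000 nM, which is a limit and not a number, so both steps give only a least size. Until now the set held only a change of configuration at a saturated ring carbon, with no step beyond the scatter, whereas here the group on the carbonyl carbon itself changes: the fact that compounds 1 and 2 differ only in the configuration as drawn.

The compounds shown leave open how far compound 3 truly lies from the other two, and whether the fall goes with the loss of the ring or with the entry of hydroxy. An open-chain amine such as dimethylamino, or a morpholine ring, on the same carbonyl carbon would bear on that question.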